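The source may report more compounds than this note shows. Statements on the series, on what has been measured and on what is new or still open speak of the compounds shown alone.

Working notes on the series.

Compound 1, `CCOc1cc(C(=O)Nc2nn[nH]n2)nc(-c2ccc(C)cc2)c1`, gives 65% in a functional assay on the whole organism with Rattus norvegicus as the target, at a dose of 1 mg/kg by the oral route; a higher number here means a stronger effect of the compound at the dose given, a lower number a weaker effect. Compound 2, `CCOc1cc(C(=O)Nc2nn[nH]n2)nc(-c2ccc(N)cc2)c1`, gives 52% in this assay. The difference between them is amino in place of methyl on an aromatic carbon, and in this assay it made a number 13 percentage points lower from compound 1 to compound 2 (beyond the scatter).

Compound 3, `Cc1ccc(-c2cccc(C(=O)Nc3nn[nH]n3)n2)cc1`, gives 67% in this assay. Its core differs from the core of compound 1 by hydrogen in place of ethoxy on an aromatic carbon, and that difference made a number 2 percentage points higher from compound 1 to compound 3 (within the scatter), so the two cores read alike in this assay.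

Compound 4, `Nc1ccc(-c2cccc(C(=O)Nc3nn[nH]n3)n2)cc1`, is not yet measured. It differs from compound 3 by amino in place of methyl on an aromatic carbon. Within the data shown here, this is the same kind of change as the one from compound 1 to compound 2, and the place described for it is the same in both cases, on an aromatic carbon of a six-membered aromatic ring of carbon only, para to a large group. Because the earlier change made a number 13 percentage points lower from compound 1 to compound 2 (beyond the scatter) on a core that behaves alike, a similar step is expected here, about a number 13 percentage points lower from compound 3 to compound 4 (beyond the scatter) in this assay.

For compound 4 the estimate in this assay is 54%, expected to fall between 40% and 66%.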

Compound 4, a percentage reported as inhibition, in the whole organism at one dose (the size of the read-out at that dose, not a potency): 62%
Beside the measured number, compound 4's estimate is 8 percentage points below it, within the range that was stated.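

In this assay, amino in place of methyl gives a number 5 percentage points lower from compound 3 to compound 4 (within the scatter), and this step agrees with the earlier one on the core of compound 1: the same change on two cores in this assay, a number 13 percentage points lower (beyond the scatter) from compound 1 to compound 2 and a number 5 percentage points lower (within the scatter) from compound 3 to compound 4, 8 percentage points apart, within the scatter of two such steps

Hydrogen in place of ethoxy, read with amino on the aromatic ring, gives a number 10 percentage points higher from compound 2 to compound 4 (within the scatter), and this step likewise agrees with its earlier counterpart: the same change on two cores in this assay, a number 2 percentage points higher (within the scatter) from compound 1 to compound 3 and a number 10 percentage points higher (within the scatter) from compound 2 to compound 4, 8 percentage points apart, within the scatter of two such steps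

Both changes therefore carry from one core to the other without a detectable difference, but this rests on one set of four compounds at a single dose, and it does not show that amino in place of methyl lowers the number on every core, since that step lies beyond the scatter on one core and within it on the other.

The compounds shown leave open how other groups at the place of methyl and amino would read, such as a hydroxyl, a carboxylic acid or a longer chain like propyl. They also leave open whether a longer alkoxy chain in place of ethoxy would follow the same pattern.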